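Carbamoyl to methoxycarbonyl on a shared core

The compounds below may be only part of what the source reports. "The series", "measured", "known", "first", "only" and "open" are said of these compounds alone.

Compound 1 `COc1ccc(-c2ccnc(Nc3ccc(C(=O)O)cc3)n2)cc1`: > 100000 nM (a limit)
Compound 2 `COc1ccc(-c2ccnc(Nc3ccc(C(N)=O)cc3)n2)cc1`: 5400 nM

Among the measured compounds shown here, in an ADME assay on Vero cells (Chlorocebus sabaeus) for cytotoxicity, read by MTT assay, with a stated time of 72 h (a lower number here means a stronger inhibitor, a higher number a weaker inhibitor), compound 2 gives the only true number, 5400 nM. The entry for compound 1 is a limit. Compound 3 `COC(=O)c1ccc(Nc2nccc(-c3ccc(OC)cc3)n2)cc1` differs from compound 2 by methoxy in place of amino on a carbonyl carbon. For the measured compounds named here, the one measured step at this place is an at least 18-fold lower number from compound 1 to compound 2 (1.26 log units; beyond the scatter), and it involves hydroxy, not methoxy. That step shows the place can matter, but it gives no firm guide here, so a modest move towards a higher number is expected. The estimated step is a 1.5-fold higher number from compound 2 to compound 3 (0.17 log units; within the scatter). Compound 3 is expected at 8000 nM, within a range of 2500 nM to 30000 nM.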

Compound 3, half-maximal inhibitory concentration: 4500 nM
For compound 3 the middle estimate is 1.8-fold (0.25 log units) above the measured one; low and high end bracket the measured number.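

At this carbonyl carbon, methoxy and amino cannot be told apart in this assay: the step is a 1.2-fold lower number from compound 2 to compound 3 (0.08 log units; within the scatter). Placing methyl on the hydroxy oxygen gives an at least 22-fold lower number from compound 1 to compound 3 (1.34 log units; beyond the scatter), so among these three compounds, only the one with the free hydroxy stands apart. The entry for compound 1 is a limit, not a true number: the limit of > 100000 nM in this assay, at which 1 of the 3 values shown sits.

On these data alone, it remains open whether a longer chain on the oxygen, such as ethoxy, or a substituted amine on the carbonyl carbon, such as methylamino, would sit with compound 2 and compound 3.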